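Chloro to bromo on the shared core: cytotoxicity notes

The source may report more compounds than this note shows. Statements on the series, on what has been measured and on what is new or still open speak of the compounds shown alone.

Measured compounds:
compound 1 `CCCCC/C=C\C[C@@]1(O)C=C(Cl)C(=O)/C1=C/C=C/CCCC(=O)OC`: 2700 nM
compound 2 `CCCCC/C=C\C[C@]1(O)C=CC(=O)/C1=C\C=C\CCCC(=O)OC`: 7900 nM

Within the data shown here, in a functional assay on HT-29 cells (Homo sapiens) for cytotoxicity, read by sulforhodamine B assay, with a stated time of 72 h (on this read-out higher numbers stand for weaker inhibition and lower numbers for stronger inhibition), compound 1 gives 2700 nM, the lowest of the two numbers so far. Among the measured compounds shown here, compound 2 differs from compound 1 in several places; in this assay compound 2 gives 7900 nM, a gap beyond the usual scatter, and since no single-change step between measured compounds exists, nothing about the size of one-place changes can be read from these two.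

Compound 3 `CCCCC/C=C\C[C@@]1(O)C=C(Br)C(=O)/C1=C/C=C/CCCC(=O)OC` is the next compound for this assay. It differs from compound 1 by bromo in place of chloro on a double-bonded ring carbon. For the measured compounds named here, with no measured step to lean on, the expected change from compound 1 to compound 3 is a 1.1-fold lower number from compound 1 to compound 3 (0.03 log units; within the scatter), a step not expected to exceed the scatter. Compound 3 is therefore estimated at 2500 nM, with a range from 1000 nM to 6000 nM.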

Compound 3, half-maximal inhibitory concentration: 5400 nM
Beside the measured number, compound 3's estimate is 2.2-fold (0.33 log units) below it; the range from low to high includes it.
By their numbers in this assay, from the lowest: compounds 1, 3 and 2 (each within the scatter of the next, the first and the last beyond it).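

In this assay, among these compounds, bromo in place of chloro on the double-bonded ring carbon gives the first single-place step, a 2.0-fold higher number from compound 1 to compound 3 (0.30 log units; within the scatter). This step lies within the scatter, so the read-out does not separate the two halogens at this position, and the change cannot be said to alter cytotoxicity. No supporting measurement bears on this step, and no cause can be assigned to it.

Still open, going by these compounds, is how an amine or a methyl group on the same ring carbon would read. On these data alone, it is also open whether a single change elsewhere on the shared core, such as a longer chain in place of the oct-2-en-1-yl group or a carboxylic acid at the chain end, would give a step beyond the scatter.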